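The compounds below may be only part of what the source reports. "The series", "measured", "known", "first", "only" and "open" are said of these compounds alone.

Measured in a physicochemical assay for solubility, at pH 7.4 (on this read-out higher numbers stand for higher solubility and lower numbers for lower solubility), so far:
compound 1 `CC[C@H]1[C@@H](N)CN1c1c(F)cc2c(=O)c(C(=O)O)cn(C3CC3)c2c1F` gives 55.9 ug/mL
compound 2 `C[C@H]1[C@H](N)CN1c1c(F)c(N)c2c(=O)c(C(=O)O)cn(C3CC3)c2c1F` gives 37.7 ug/mL
compound 3 `CC[C@H]1[C@@H](N)CN1c1cc2c(cc1F)c(=O)c(C(=O)O)cn2C1CC1` gives 42.2 ug/mL

Compound 1 stands level with the other two: its gaps to compound 2 and compound 3 both lie within the scatter. Compound 4 `C[C@H]1N(c2c(F)cc3c(=O)c(C(=O)O)cn(C4CC4)c3c2F)C[C@]1(C)N` has the same atoms as compound 1, joined differently, and the change is a group of 7 heavy atoms (5 carbon, 2 nitrogen; one four-membered non-aromatic ring with 1 hetero atom) in place of a group of 7 heavy atoms (5 carbon, 2 nitrogen; one four-membered non-aromatic ring with 1 hetero atom), on an aromatic carbon on the aromatic carbon ortho to two fluoro groups. Among the compounds with values here, no measured step touches this group. Within the data shown here, the only step available, a 1.3-fold lower number from compound 1 to compound 3 (0.12 log units; within the scatter) for hydrogen in place of fluoro, is a different change and stays within the scatter. The estimated step is a 1.1-fold lower number from compound 1 to compound 4 (0.05 log units; within the scatter) and nothing beyond the scatter is expected from it in this assay on this evidence. For compound 4 the estimated value is 50 ug/mL with an expected range of 25 ug/mL to 100 ug/mL in this read-out.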

Compound 4, solubility: 3.3 ug/mL
Compound 4: middle estimate off by 15-fold (1.18 log units), on the high side; measured number outside the range, below it.
By their numbers in this assay, from the lowest: compound 4; then compounds 2, 3 and 1 (each within the scatter of the next).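

In this assay, the group on the aromatic carbon ortho to two fluoro groups can matter even when the atom count stays the same: the rearranged group gives a 17-fold lower number from compound 1 to compound 4 (1.23 log units; beyond the scatter) with matching heavy-atom, donor and acceptor counts. Within the data shown here, earlier steps stayed within the scatter, so this is the first large change. No available evidence bears on the origin of this step. Open, on these data alone, is whether the step persists with hydrogen in place of fluoro on the shared core. Also open, as far as these compounds go, is whether a dimethylamino group in place of the primary amine on the four-membered ring would track compound 1 or compound 4.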